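The source may hold more compounds than are shown below. What is called first, only, known or untested is meant among the compounds shown, and "the series" means these compounds.

Measured compounds:
Compound 1 `O=C(CCC(=O)OCCCCCCSc1ccc([N+](=O)[O-])c2nonc12)Nc1ccccc1Cl` gives 15500 nM in an assay on isolated protein for inhibition of glutathione S-transferase P (Homo sapiens), with a stated time of 10 min; on this read-out higher numbers stand for weaker inhibition and lower numbers for stronger inhibition.
Compound 2 `O=C(CCC(=O)OCCCCCCSc1ccc([N+](=O)[O-])c2nonc12)Nc1ccc(F)cc1` gives 8570 nM in this assay.
Compound 3 `O=C(CCC(=O)OCCCCCCSc1ccc([N+](=O)[O-])c2nonc12)Nc1ccc(C(F)(F)F)cc1` gives 5050 nM in this assay.

Compound 3 has the lowest number of the three. Its distance from compound 1 is clear: a 3.1-fold lower number from compound 1 to compound 3 (0.49 log units; beyond the scatter). Its distance from compound 2 is not: a 1.7-fold lower number from compound 2 to compound 3 (0.23 log units; within the scatter), and the step of a 1.8-fold lower number from compound 1 to compound 2 (0.26 log units; within the scatter) also stays within the scatter. The three measured steps all concern exchanges of one substituent on the phenyl ring of the amide nitrogen, and even the largest of them is modest.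

Compound 4 `O=C(CCC(=O)N1CCOCC1)OCCCCCCSc1ccc([N+](=O)[O-])c2nonc12` is a different kind of change: morpholin-4-yl in place of (4-(trifluoromethyl)phenyl)amino on a carbonyl carbon. Within the data shown here, no measured step touches this part of the molecule; the three compounds only show that varying the group on the phenyl ring shifts the number by a modest amount at most. Removing that phenyl ring altogether, together with its amide hydrogen, is therefore unsupported by precedent here, and the expectation must carry a wide range. Given that the shared core is unchanged, compound 4 is estimated to land near the weaker end of the measured compounds, at 12000 nM, with a range from 3000 nM to 50000 nM. This estimate corresponds to an expected step of a 2.4-fold higher number from compound 3 to compound 4 (0.38 log units; beyond the scatter).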

Compound 4, half-maximal inhibitory concentration: 330 nM
Beside the measured number, compound 4's estimate is 36-fold (1.56 log units) above it, and the stated range ends above it.
By their numbers in this assay, from the lowest: compound 4; then compounds 3, 2 and 1 (each within the scatter of the next, the first and the last beyond it).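

In this assay, the group on this carbonyl carbon turns out to matter far more than the substituents on the phenyl ring, with morpholin-4-yl giving three large steps (a 15-fold lower number from compound 3 to compound 4 (1.18 log units; beyond the scatter); a 26-fold lower number from compound 2 to compound 4 (1.41 log units; beyond the scatter); a 47-fold lower number from compound 1 to compound 4 (1.67 log units; beyond the scatter)). Each of these is well beyond the largest step among the phenyl compounds (a 3.1-fold lower number from compound 1 to compound 3 (0.49 log units; beyond the scatter)), and compound 4 is the most potent of the four, so neither an aromatic ring nor an amide hydrogen on this carbonyl carbon is needed for inhibition in this series. No measurement is at hand that explains why the exchange has an effect of this size.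

This one exchange removes the aromatic ring and the amide hydrogen and brings in a non-aromatic ring with a ring oxygen, all at once, so the compounds shown cannot say which of these changes carries the step. A piperidin-1-yl group would keep a saturated ring without that oxygen, and a cyclohexylamino group would keep the amide hydrogen without an aromatic ring, so these two would begin to separate the changes.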